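Swapping a halogen on one aryl ring of the shared core

A few compounds are considered here, and "the series" means these few. Any claim that something is new, unique, unknown or untested is made for them only; others in the source may bear on it.

Measured compounds:
- Compound 1, `Cc1ccc(-c2cc3nc(-c4ccc(F)cc4)cc(N)n3n2)cc1`: 65%
- Compound 2, `Nc1cc(-c2ccc(Br)cc2)nc2cc(-c3ccc(Cl)cc3)nn12`: 60%
- Compound 3, `Cc1ccc(-c2cc(N)n3nc(-c4ccc(Cl)cc4)cc3n2)cc1`: 75%

All three were tested in a functional assay on the whole organism (strain Wistar) for inhibition, with Rattus norvegicus as the target, read by paw edema, with stated times of 30 min and 2 h, at a dose of 50 mg/kg by the oral route; on this read-out lower numbers stand for less inhibition and higher numbers for more inhibition at the one dose given (going by the name of the read-out). Compound 3 stands highest of the three numbers, but only its gap to compound 2 lies beyond the scatter; compound 1 is within the scatter of compound 3. For the measured compounds named here, the one single-point step among them, a number 15 percentage points higher from compound 2 to compound 3 (beyond the scatter), concerns the other aryl ring and not the halogen that changes next.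

Compound 4, `Cc1ccc(-c2cc(N)n3nc(-c4ccc(Br)cc4)cc3n2)cc1`, differs from compound 3 by bromo in place of chloro on an aromatic carbon. Going by the values given here, no measured step bears directly on this change. The nearest comparison is compound 1 against compound 3, where fluoro and chloro sit at the same place and the two values lie within the scatter of each other, so the data give no sign that the halogen at this position moves the read-out much.

For compound 4 the expected change is therefore a number 5 percentage points lower from compound 3 to compound 4 (within the scatter), none beyond the scatter. The estimate for compound 4 in this assay is 70%, with a range from 55% to 85%.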

Compound 4, a percentage reported as inhibition, in the whole organism at one dose (the size of the read-out at that dose, not a potency): 76.3%
For compound 4 the middle estimate is 6.3 percentage points below the measured one, within the range that was stated.
By their numbers in this assay, from the lowest: compounds 2, 1, 3 and 4 (each within the scatter of the next, the first and the last beyond it).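

For the compounds shown here, the change from 4-chlorophenyl to 4-bromophenyl gives the first direct reading of a halogen swap at this place, and in this assay it comes out as a number 1.3 percentage points higher from compound 3 to compound 4 (within the scatter) with all else in the molecule unchanged. Chloro and bromo, on an aromatic carbon para to a large group, therefore cannot be told apart by this read-out at the one dose given, and compound 4 stays level with compound 3 near the top of the series, clearly separated only from compound 2. Nothing available explains why the two halogens give such similar results.

These compounds leave open whether the same place would accept something other than a halogen, such as an amine, a carboxylic acid or a longer chain, or whether the read-out would then fall. They also leave open whether compound 3 and compound 4 would stay level at other doses, as a single-dose percentage says nothing about potency.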